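Removing a hydroxymethyl group from a quinoline-type alkyne

The source may report more compounds than this note shows. Statements on the series, on what has been measured and on what is new or still open speak of the compounds shown alone.

Measured compounds:
compound 1, `OCC#CCSc1cnc2ccccc2c1[Se]CC#CCBr`: 4.6 ug/mL
compound 2, `OCC#CCSc1cnc2ccccc2c1[Se]CC#CCO`: 4.3 ug/mL
compound 3, `C#CC[Se]c1c(SCC#CCO)cnc2ccccc12`: 6.8 ug/mL

Three compounds were tested in a functional assay on B16 cells (Mus musculus) for cytotoxicity, read by sulforhodamine B assay, with a stated time of 72 h (on this read-out higher numbers stand for weaker inhibition and lower numbers for stronger inhibition), and all three gave numbers close together. Compound 1 and compound 2 share a core and differ only by bromo in place of hydroxy on a saturated chain carbon bound to a triple-bonded carbon; that difference made a 1.1-fold lower number from compound 1 to compound 2 (0.03 log units; within the scatter). Compound 3 arises from compound 2 by hydrogen in place of hydroxymethyl on a triple-bonded carbon, which gave a 1.6-fold higher number from compound 2 to compound 3 (0.20 log units; within the scatter).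

Compound 4, `C#CCSc1cnc2ccccc2c1[Se]CC#CCBr`, has not yet been measured. It arises from compound 1 by hydrogen in place of hydroxymethyl on a triple-bonded carbon, the same change as from compound 2 to compound 3, at the same place. Resting on that one earlier step, compound 4 is expected to give roughly a 1.6-fold higher number from compound 1 to compound 4 (0.20 log units; within the scatter), a change of the same size as a 1.6-fold higher number from compound 2 to compound 3 (0.20 log units; within the scatter). The estimated number for compound 4 in this assay is therefore 7.3 ug/mL, with 3.5 ug/mL to 15 ug/mL as the likely range.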

Compound 4, concentration for 50% inhibition: 4.2 ug/mL
Compound 4: the middle estimate sits 1.7-fold (0.24 log units) above what was measured, and the stated range covers the measured number.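

In this assay, putting hydrogen in place of hydroxymethyl on the triple-bonded carbon gave a 1.1-fold lower number from compound 1 to compound 4 (0.04 log units; within the scatter). Set beside the earlier step, the two cores show no measurable disagreement: the same change on two cores in this assay, a 1.6-fold higher number (0.20 log units; within the scatter) from compound 2 to compound 3 and a 1.1-fold lower number (0.04 log units; within the scatter) from compound 1 to compound 4, 1.7-fold (0.24 log units) apart, within the scatter of two such steps This shows that the change produced no step beyond the scatter on either core, but it does not show that the change has exactly the same effect on both, or that it would stay this small on any other core in the series.

The compounds shown leave open whether an amine or a longer chain on that triple-bonded carbon would shift the number beyond the scatter. They also leave open how the change behaves in any other cell type.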